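Hydroxy for dimethylamino on the thiazole chain carbon

A few compounds are considered here, and "the series" means these few. Any claim that something is new, unique, unknown or untested is made for them only; others in the source may bear on it.

Compound 3 `CN(C)Cc1csc(NC(=O)c2cc(C(C)(C)C)nn2Cc2ccccc2)n1` gives 4.2 in a physicochemical assay for lipophilicity, read by HPLC, at pH 7.4 (a lower number here means a more polar compound, a higher number a more lipophilic compound), the second highest of the three numbers: compound 1 `CC(C)(C)c1cc(C(=O)Nc2ccccc2)n(Cc2ccccc2)n1` gives 4.7 and compound 2 `CNCc1csc(NC(=O)c2cc(C(C)(C)C)nn2Cc2ccccc2)n1` gives 3.8. Compound 4 `CC(C)(C)c1cc(C(=O)Nc2nc(CO)cs2)n(Cc2ccccc2)n1` differs from compound 3 in one place: hydroxy in place of dimethylamino on a saturated chain carbon bound to an aromatic carbon. One measured step changes the same saturated chain carbon bound to an aromatic carbon, a number 0.40 log units higher from compound 2 to compound 3 (beyond the scatter); the wider comparison a number 0.50 log units lower from compound 1 to compound 3 (beyond the scatter) swaps the whole ring and does not separate the chain group from the rest. Going by the values given here, no measured step shows a hydroxy entering, so the hydrogen-bond donor it brings has no precedent here. A modest downward step is expected, and compound 4 is estimated at 3.9 (range 3.3 to 4.5), an expected step of a number 0.30 log units lower from compound 3 to compound 4 (within the scatter).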

Compound 4, distribution coefficient: 3.4
Beside the measured number, compound 4's estimate is 0.50 log units above it, and the stated range covers the measured number.
By their numbers in this assay, from the lowest: compound 4; then compound 2; then compound 3; then compound 1.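

In this assay, the three groups on the saturated chain carbon bound to an aromatic carbon now form an order, with hydroxy lowest, through a number 0.80 log units lower from compound 3 to compound 4 (beyond the scatter) and a number 0.40 log units lower from compound 2 to compound 4 (beyond the scatter), both against the amine-bearing compounds. Going by these compounds alone, replacing phenyl on the amide-type nitrogen with 4-(hydroxymethyl)-1,3-thiazol-2-yl gives a number 1.30 log units lower from compound 1 to compound 4 (beyond the scatter), the only step in the set printed as large. Nothing on hand explains these steps.

Open, going by these compounds, is where methoxy, a primary amine or a carboxylic acid on the same chain carbon would fall in this order. Also open, on these data alone, is how a longer chain carrying the hydroxy would read.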